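The source may hold more compounds than are shown below. What is called first, only, known or untested is meant among the compounds shown, and "the series" means these compounds.

In a functional assay on HT-1080 cells (Homo sapiens) for cytotoxicity, read by MTT assay, with a stated time of 72 h (on this read-out higher numbers stand for weaker inhibition and lower numbers for stronger inhibition), compound 1 (`COc1ccc(/C=C2\CCC/C(=C\c3ccc(Cl)cc3)C2=O)cc1OC`) gives 4800 nM, compound 2 (`COc1ccc(/C=C2\CCC/C(=C\c3ccccc3Br)C2=O)cc1OC`) gives 8400 nM and compound 3 (`COc1ccc(/C=C2\CCC/C(=C\c3ccc(OC)c(OC)c3)C2=O)cc1`) gives 7200 nM, so compound 3 stands within the scatter of both others. Compound 4 (`COc1ccc(/C=C2\CCC/C(=C\c3ccc(O)cc3)C2=O)cc1OC`) has hydrogen in place of methyl on an oxygen on an aromatic ring, turning 4-methoxyphenyl to 4-hydroxyphenyl: hydrogen in place of methyl on an oxygen on an aromatic ring. Among the compounds with values here, no measured step makes this exact change. The closest are a 1.5-fold higher number from compound 1 to compound 3 (0.18 log units; within the scatter) and a 1.2-fold lower number from compound 2 to compound 3 (0.07 log units; within the scatter), both of which alter the aryl group that carries this methoxy, and neither leaves the scatter. No step beyond the scatter is therefore expected in this assay, in either direction. The estimated step is a 1.2-fold lower number from compound 3 to compound 4 (0.08 log units; within the scatter). For compound 4 the expected value is 6000 nM, within an estimated range of 2800 nM to 12000 nM.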

Compound 4, half-maximal inhibitory concentration: 16800 nM
Estimate against measurement, compound 4: 2.8-fold (0.45 log units) below; measured number above the stated range.
By their numbers in this assay, from the lowest: compounds 1, 3, 2 and 4 (each within the scatter of the next, the first and the last beyond it).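

In this assay, within the data shown here, the earlier steps all stayed within the scatter, whereas hydrogen in place of methyl on this oxygen gives a 2.3-fold higher number from compound 3 to compound 4 (0.37 log units; beyond the scatter) and so goes modestly beyond it. Hydroxy in place of chloro likewise gives a 3.5-fold higher number from compound 1 to compound 4 (0.54 log units; beyond the scatter) and also goes modestly beyond it, while the 2-bromophenyl comparison, a 2.0-fold higher number from compound 2 to compound 4 (0.30 log units; within the scatter), stays within it. Nothing available explains this result.

On these data alone, whether an amine or a carboxylic acid on this aromatic carbon would read like the hydroxy or like the methoxy remains open.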